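A bromo substituent on the anilino ring of a weak inhibitor

The compounds below may be only part of what the source reports. "The series", "measured", "known", "first", "only" and "open" are said of these compounds alone.

Compound 1 `Cc1ccc(S(=O)(=O)Cc2nc(Nc3ccccc3)c3ccccc3n2)cc1` gave no result in a functional assay on K562 cells (Homo sapiens) for cytotoxicity, read by flow cytometry, with a stated time of 72 h (a higher number here means a weaker inhibitor, a lower number a stronger inhibitor), and is recorded as "nd(insoluble)" (no result reported). Compound 2 `CC(C)=Cc1nc(Nc2ccccc2)c2cc([N+](=O)[O-])ccc2n1` reached only the limit of this assay, reported as > 125000 nM. That limit, (the limit of > 125000 nM in this assay, at which 1 of the 2 values shown sits), is where compound 2 stands. Compound 3 `CC(C)=Cc1nc(Nc2cccc(Br)c2)c2cc([N+](=O)[O-])ccc2n1` differs from compound 2 by bromo in place of hydrogen on an aromatic carbon. Within the data shown here, no measured step on this change exists here, so the expected step of an at least 1.2-fold lower number from compound 2 to compound 3 (0.09 log units; that floor lies within the scatter) is set small and within the scatter, in no firm direction. Compound 3 is therefore estimated at 100000 nM in this assay, with a likely range from 20000 nM to 500000 nM.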

Compound 3, half-maximal inhibitory concentration: > 62000 nM
Compound 3 gave a limit, no number; the forecaster's own chance of this, stated with the estimate: 70%; the middle value is on the limit's open side.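

Among these compounds, compound 2 and compound 3 both gave only limits in this assay, so no step between them can be read. On these data alone, whether bromo in place of hydrogen changes the half-maximal inhibitory concentration at all, and in which direction, remains open.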